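Fluoro for methyl on the cycloheptyl compounds

This account rests on a few compounds, and the source may have more. Where it says the series, first, only, none or still open, it means among the compounds named here.

Measured in a functional assay on PC-3 cells (Homo sapiens) for cytotoxicity, read by WST assay, with a stated time of 72 h; on this read-out higher numbers stand for weaker inhibition and lower numbers for stronger inhibition:
- compound 1 `Cc1cccc2c1NC(=O)C2(c1ccc(O)cc1)C1CCCCCC1`: > 1000 nM (a limit)
- compound 2 `Cc1cc(C)c2c(c1)C(c1ccc(O)cc1)(c1ccc(F)cc1)C(=O)N2`: 209 nM
- compound 3 `Cc1cc(C)c2c(c1)C(c1ccc(O)cc1)(C1CCCCCC1)C(=O)N2`: > 1000 nM (a limit)

Compound 3 gives > 1000 nM, which is a limit and not a number. It therefore sits at the limit of > 1000 nM in this assay, at which 2 of the 3 values shown sit.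

The next compound to consider is compound 4 `Cc1cc(F)cc2c1NC(=O)C2(c1ccc(O)cc1)C1CCCCCC1`. It carries fluoro in place of methyl on an aromatic carbon, meta to a fused ring and para to a fused ring: fluoro in place of methyl on an aromatic carbon. The cycloheptyl group stays.

Among the measured compounds shown here, two measured steps bear on this change. The closer one in kind, methyl in place of hydrogen on an aromatic carbon, is a step that the two limits leave unreadable from compound 1 to compound 3, so it gives no size to carry over. For the measured compounds named here, the only readable step is an at least 4.7-fold higher number from compound 2 to compound 3 (0.67 log units; beyond the scatter), with cycloheptyl in place of 4-fluorophenyl on a saturated ring carbon. Compound 4 keeps the cycloheptyl group of compound 3, and both measured compounds with that group, compound 1 and compound 3, gave only limits. Going by the values given here, none of the measured compounds goes against this pattern, though there are few of them.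

In this assay no step beyond the scatter is expected, and the estimated step is a step that the limit leaves unreadable from compound 3 to compound 4. A limit is the more likely report. Compound 4 is expected at 1500 nM, with an estimated range from 600 nM to 5000 nM.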

Compound 4, half-maximal inhibitory concentration: > 1000 nM
Compound 4 ended at the assay's limit; the forecaster's own chance of this, stated with the estimate: 75%; the middle value does not contradict the limit.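

In this assay compound 4 gives > 1000 nM, which is a limit and not a number. No new step can be read from compound 1 or compound 3 to compound 4, since each of the three compounds gives only a limit: the limit of > 1000 nM in this assay, at which 3 of the 4 values shown sit.

The compounds shown leave open whether fluoro in place of methyl on an aromatic carbon changes the read-out of the cycloheptyl compounds at all.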